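The source may hold more compounds than are shown below. What is called first, only, known or untested is meant among the compounds shown, and "the series" means these compounds.

In a functional assay with Cavia porcellus as the target (a lower number here means that less compound is needed, a higher number that more compound is needed for the effect), compound 1 `COC(=O)c1c[nH]c(C)c1C(=O)c1ccccc1Cc1ccccc1` gives 144 nM and compound 2 `COC(=O)c1c(C)[nH]c(C)c1C(=O)c1ccccc1F` gives 70000 nM as the higher of the two numbers, a gap well beyond the scatter. These two compounds differ in more than one place, so the gap cannot be assigned to any single change. Compound 3 `COC(=O)c1c(C)[nH]c(C)c1C(=O)c1ccccc1C` departs from compound 2 by methyl in place of fluoro on an aromatic carbon and so has methyl in place of fluoro on an aromatic carbon, ortho to a large group. Going by the values given here, no measured pair isolates a change in one place, which leaves the size of this step uncertain. A moderate move towards a lower number is expected, while compound 1 at 144 nM remains far out of reach. The expected change is a 5.8-fold lower number from compound 2 to compound 3 (0.77 log units; beyond the scatter) and it may only just clear the scatter. For compound 3 the estimated value is 12000 nM with an expected range from 1500 nM to 70000 nM on current evidence.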

Compound 3, half-maximal effective concentration: 9470 nM
The estimate for compound 3 lay 1.3-fold (0.10 log units) above the measured number; low and high end bracket the measured number.
By their numbers in this assay, from the lowest: compound 1; then compound 3; then compound 2.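

In this assay, going by these compounds alone, this is the first step confined to one place: a 7.4-fold lower number from compound 2 to compound 3 (0.87 log units; beyond the scatter). The aromatic carbon ortho to a large group therefore responds to the identity of its substituent, even though fluoro and methyl are each a single heavy atom. Neither group brings a ring, a hydrogen-bond donor, a hydrogen-bond acceptor or a net charge, so none of these counts differs across the step, and no available measurement accounts for its size.

From the compounds shown here alone, with only fluoro and methyl compared at this position, it remains open how chloro, methoxy or an ethyl chain would read there. Compound 1 differs from compound 3 in more than one place, so the steps leading to compound 1 cannot be read, and the contribution of each difference remains unassigned.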